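A Furan for a Fluorophenyl at One Ring Carbon

The source may hold more compounds than are shown below. What is called first, only, known or untested is meant among the compounds shown, and "the series" means these compounds.

Compound 1 `CN1C[C@@H](c2ccc(F)cc2)[C@@]2(Cc3ccccc3C2=O)[C@@]12C(=O)Nc1ccccc12` is one of two compounds tested in a functional assay on the whole organism (strain Wister albino) for inhibition, with Rattus norvegicus as the target, read by paw edema, with a stated time of 1 h, at a dose of 50 mg/kg by the intraperitoneal route; on this read-out higher numbers stand for more inhibition at the one dose given (going by the name of the read-out) and lower numbers for less inhibition. In this assay compound 1 gives 40.6%, the lowest of the two numbers. Compound 2 `CN1C(=O)[C@@]2(c3ccccc31)N(C)C[C@@H](c1ccc(Cl)cc1)[C@@]21Cc2ccccc2C1=O` gives 47.2%, a value within the usual scatter of that of compound 1, so the two cannot be told apart. Compound 3 `CN1C[C@@H](c2ccco2)[C@@]2(Cc3ccccc3C2=O)[C@@]12C(=O)Nc1ccccc12` has not been measured. It differs from compound 1 in one place: furan-2-yl in place of 4-fluorophenyl on a saturated ring carbon. Among the compounds with values here, no measured pair shows what such a change does here, so the step from compound 1 to compound 3 is expected to stay within the scatter, in no clear direction. Compound 3 is therefore expected to give 40%, between 25% and 55%, an expected step of a number 0.6 percentage points lower from compound 1 to compound 3 (within the scatter).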

Compound 3, a percentage reported as inhibition, in the whole organism at one dose (the size of the read-out at that dose, not a potency): 48.8%
Compound 3: middle estimate off by 8.8 percentage points, on the low side; the range from low to high includes it.
By their numbers in this assay, from the lowest: compounds 1, 2 and 3 (each within the scatter of the next).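

In this assay, furan-2-yl in place of 4-fluorophenyl on this saturated ring carbon gives a number 8.2 percentage points higher from compound 1 to compound 3 (within the scatter). The aromatic ring here can therefore be a five-membered ring with an oxygen rather than a six-membered ring of carbon only, with no change that stands clear of the scatter. Nothing measured offers a reason for this result. Still open, as far as these compounds go, is whether this carbon needs an aromatic ring at all, which a cyclohexyl ring or a simple amine would test. Also open, from the compounds shown here alone, is whether any group here moves the inhibition beyond the scatter.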